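This account rests on a few compounds, and the source may have more. Where it says the series, first, only, none or still open, it means among the compounds named here.

Measured compounds:
Compound 1 `O=c1cc(Cn2ccnc2)c2ccc(OCc3cc(F)cc(F)c3)cc2o1` gives 45 nM in an assay on V79MZh11B1 cells for inhibition of cytochrome P450 11B1, mitochondrial (Homo sapiens), read by HPLC, with a stated time of 25 min; on this read-out lower numbers stand for stronger inhibition and higher numbers for weaker inhibition.
Compound 2 `CC(C)Oc1ccc(COc2ccc3c(Cn4ccnc4)cc(=O)oc3c2)cc1` gives 48 nM in this assay.

Compound 1 has the lower of the two numbers, but compound 2 sits within the scatter of it, so the two cannot be ordered. Compound 3 `Cc1cccc(COc2ccc3c(Cn4ccnc4)cc(=O)oc3c2)c1` is not yet measured. It differs from compound 1 by 3-methylphenyl in place of 3,5-difluorophenyl on a saturated chain carbon bound to an oxygen on an aromatic ring. Going by the values given here, no step between two measured compounds isolates this change. What the data do show is that compound 1 and compound 2 carry different groups on the saturated chain carbon bound to an oxygen on an aromatic ring and give numbers within the scatter of each other; nothing more can be read from that pair. For compound 3, the step of a 1.3-fold higher number from compound 1 to compound 3 (0.12 log units; within the scatter) is expected to stay within the scatter, with at most a slight rise in the number. Compound 3 is therefore estimated at 60 nM, with a range from 25 nM to 150 nM.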

Compound 3, half-maximal inhibitory concentration: 45 nM
The estimate for compound 3 lay 1.3-fold (0.12 log units) above the measured number, within the range that was stated.
By their numbers in this assay, from the lowest: compounds 1, 3 and 2 (each within the scatter of the next).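

In this assay, going by these compounds alone, the exchange of 3,5-difluorophenyl for 3-methylphenyl on a saturated chain carbon bound to an oxygen on an aromatic ring gives no change at the digits printed from compound 1 to compound 3 (within the scatter) and is the first single-place step. The two fluorine atoms of compound 1 are therefore not required to hold the number at this level, at least when a single methyl group takes their place. This is one exchange on one core, so it sets no general rule for this position.
No measurement at hand explains why the number stays where it is.

From the compounds shown here alone, it remains open whether a plain phenyl group would also stay within the scatter of compound 1. Also open, going by these compounds, is what a carboxylic acid or an amine on this ring, or a longer chain in place of the saturated chain carbon, would do to the number.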